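Chloro to Bromo on the Pendant Phenyl Ring

The compounds below may be only part of what the source reports. "The series", "measured", "known", "first", "only" and "open" are said of these compounds alone.

Among the compounds with values here, in a functional assay on HepG2 cells (Homo sapiens) for inhibition, read by MTT assay, with a stated time of 72 h (on this read-out higher numbers stand for weaker inhibition and lower numbers for stronger inhibition), compound 2 `O=C(Nc1ccc(Oc2ccnc3[nH]ccc23)c(F)c1)c1cn(-c2ccc(Cl)cc2)c2ccccc2c1=O` gives 380 nM and stands at one end of the two numbers measured so far; the other, compound 1 `O=C(Nc1ccc(Oc2ccnc3[nH]ccc23)c(F)c1)c1cn(-c2ccccc2)c2ccccc2c1=O`, gives 760 nM, and the gap between them lies within the scatter. Compound 3 `O=C(Nc1ccc(Oc2ccnc3[nH]ccc23)c(F)c1)c1cn(-c2ccc(Br)cc2)c2ccccc2c1=O` differs from compound 2 by bromo in place of chloro on an aromatic carbon. Within the data shown here, the only measured step, a 2.0-fold lower number from compound 1 to compound 2 (0.30 log units; within the scatter), concerned a different exchange and stayed within the scatter, so it offers little guidance. Compound 3 is therefore expected to stay close, with an expected step of no change at the digits printed from compound 2 to compound 3 (within the scatter). Compound 3 is estimated at 380 nM, within 190 nM to 760 nM.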

Compound 3, half-maximal inhibitory concentration: 710 nM
Estimate against measurement, compound 3: 1.9-fold (0.27 log units) below, within the range that was stated.
By their numbers in this assay, from the lowest: compounds 2, 3 and 1 (each within the scatter of the next).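

In this assay, the exchange of one halogen for the other gives a 1.9-fold higher number from compound 2 to compound 3 (0.27 log units; within the scatter), and bromo in place of hydrogen gives a 1.1-fold lower number from compound 1 to compound 3 (0.03 log units; within the scatter). With a second halogen now at this position, hydrogen, chloro and bromo on this carbon cannot be told apart in this assay, as every step among them lies within the scatter. No available evidence bears on this result.

From the compounds shown here alone, whether an amine, a carboxylic acid or a methoxy group on this carbon would move the number beyond the scatter stays open. So does whether chloro or bromo would behave alike elsewhere on the phenyl ring.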